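This account rests on a few compounds, and the source may have more. Where it says the series, first, only, none or still open, it means among the compounds named here.

Measured compounds: compound 1 `Cc1nc2c(OCc3ccccc3)cccn2c1N`, 99%; compound 2 `Cc1nc2c(OCc3ccccn3)cccn2c1N`, 16%.

In a functional assay on the whole organism with Rattus norvegicus as the target, at a dose of 40 mg/kg by the intraperitoneal route (on this read-out higher numbers stand for more inhibition at the one dose given (going by the name of the read-out) and lower numbers for less inhibition), compound 2 stands lowest of the two numbers; its nearest neighbour is compound 1 at 99%. Compound 3 `Cc1nc2c(OCc3cccs3)cccn2c1N` is not yet measured and differs from compound 2 by thiophen-2-yl in place of pyridin-2-yl on a saturated chain carbon bound to an oxygen on an aromatic ring. Among the measured compounds shown here, the only measured step at this place is a number 83 percentage points lower from compound 1 to compound 2 (beyond the scatter). Because a number 83 percentage points lower from compound 1 to compound 2 (beyond the scatter) was so large, a further change of the group here is expected to move the read-out strongly again, most plausibly upward from compound 2, though the direction is uncertain. Compound 3 is expected to give about 60%, within 20% to 99%. This means an expected step of a number 44 percentage points higher from compound 2 to compound 3 (beyond the scatter).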

Compound 3, a percentage reported as inhibition, in the whole organism at one dose (the size of the read-out at that dose, not a potency): 70%
Estimate against measurement, compound 3: 10 percentage points below; low and high end bracket the measured number.
By their numbers in this assay, from the lowest: compound 2; then compound 3; then compound 1.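

In this assay, the loss seen with pyridin-2-yl on the saturated chain carbon bound to an oxygen on an aromatic ring does not extend to every ring with a hetero atom: thiophen-2-yl brings a number 54 percentage points higher from compound 2 to compound 3 (beyond the scatter) and recovers much of the read-out. It does not fully match phenyl, with a number 29 percentage points lower from compound 1 to compound 3 (beyond the scatter) as the modest remaining step. Nothing available explains either step. Going by these compounds, it remains open how furan-2-yl, cyclohexyl or a longer chain in place of these rings would behave at this place.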